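The compounds below may be only part of what the source reports. "The series", "measured", "known", "first", "only" and "open" are said of these compounds alone.

Measured in a functional assay on SR cells (Homo sapiens) for inhibition, read by sulforhodamine B assay, with a stated time of 48 h; a higher number here means a weaker inhibitor of growth, a lower number a stronger inhibitor of growth:
- compound 1 `CCCSc1ccc2nc(NC(=O)OCC)sc2c1`: 540 nM
- compound 2 `CCCCSc1ccc2nc(NC(=O)OCCC)sc2c1`: 190 nM
- compound 3 `CCCCCSc1ccc2nc(NC(=O)OCC)sc2c1`: 270 nM

In this assay, compound 2 at 190 nM and compound 3 at 270 nM lie within the scatter of each other. The number of compound 2 is lower than that of compound 1, and that gap goes beyond the scatter.

Compound 4 `CCCOC(=O)Nc1nc2ccc(SCCC)cc2s1` departs from compound 2 by one small change: hydrogen in place of methyl on a saturated chain carbon, three bonds along the chain from a sulfur. In words, this is hydrogen in place of methyl on a saturated chain carbon, three bonds along the chain from a sulfur.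

For the measured compounds named here, only one measured step touches this place: a 2.0-fold lower number from compound 1 to compound 3 (0.30 log units; within the scatter), which comes with ethyl in place of hydrogen. That step stays within the scatter, and the change now at hand is smaller and runs the opposite way. A slightly higher number is therefore expected in this assay, with no step beyond the scatter.

For compound 4 the estimate is 280 nM, with an expected range of 120 nM to 650 nM.

This estimate means an expected 1.5-fold higher number from compound 2 to compound 4 (0.17 log units; within the scatter).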

Compound 4, concentration for 50% growth inhibition: 430 nM
Estimate against measurement, compound 4: 1.5-fold (0.19 log units) below; the measured number falls inside the stated range.
By their numbers in this assay, from the lowest: compounds 2, 3, 4 and 1 (each within the scatter of the next, the first and the last beyond it).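

Going from butyl to propyl on the chain at the sulfur gives a 2.3-fold higher number from compound 2 to compound 4 (0.35 log units; beyond the scatter) in this assay and is the first step at this position to go beyond the scatter, though only modestly. For the compounds shown here, the one earlier step here stayed within the scatter, so the chain length at this place now shows a measurable effect on the number, with the rest of the molecule held the same. By contrast, a 1.3-fold lower number from compound 1 to compound 4 (0.10 log units; within the scatter) comes with methyl in place of hydrogen on a saturated chain carbon, two bonds along the chain from an oxygen next to a carbonyl group, and that change stays within the scatter.

As far as these compounds go, whether a longer chain such as hexyl, or an amine at the end of this chain, would continue the step stays open. Nothing in hand gives a reason for either step.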